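The source may hold more compounds than are shown below. What is called first, only, known or untested is meant among the compounds shown, and "the series" means these compounds.

In a functional assay on cells (leukaemia cell line, Homo sapiens) for inhibition, read by sulforhodamine B assay, with a stated time of 48 h (a lower number here means a stronger inhibitor of growth, a higher number a weaker inhibitor of growth), compound 1 `O=S(=O)(Nc1ccc(Cl)c(Cl)c1)c1ccc(-c2cnc(C3CC3)o2)cc1` gives 416 nM, compound 2 `O=S(=O)(Nc1cc(Cl)ccc1Cl)c1ccc(-c2cnc(C3CC3)o2)cc1` gives 1020 nM and compound 3 `O=S(=O)(Nc1ccc(I)c(Cl)c1)c1ccc(-c2cnc(C3CC3)o2)cc1` gives 1010 nM. Compound 3 therefore stands level with compound 2, and both are weaker than compound 1. Compound 4 `Cc1cc(Cl)cc(NS(=O)(=O)c2ccc(-c3cnc(C4CC4)o3)cc2)c1` keeps the shared core but has 3-chloro-5-methylphenyl in place of 3-chloro-4-iodophenyl on a sulfonamide nitrogen. Three measured swaps of this same group bear on the change. Two were modest, a 2.5-fold higher number from compound 1 to compound 2 (0.39 log units; beyond the scatter) and a 2.4-fold higher number from compound 1 to compound 3 (0.39 log units; beyond the scatter), and one, a 1.0-fold lower number from compound 2 to compound 3 (0.00 log units; within the scatter), stayed within the scatter. Among the measured compounds shown here, with such small steps as the only guide, no large shift is expected. The expected change is a 1.3-fold lower number from compound 3 to compound 4 (0.10 log units; within the scatter), which would not go beyond the scatter. Compound 4 is estimated at 800 nM, with an expected range of 350 nM to 1900 nM.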

Compound 4, concentration for 50% growth inhibition: 175 nM
Beside the measured number, compound 4's estimate is 4.6-fold (0.66 log units) above it; measured number below the stated range.
By their numbers in this assay, from the lowest: compound 4; then compound 1; then compounds 3 and 2 (each within the scatter of the next).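

In this assay the 3-chloro-5-methylphenyl group on the sulfonamide nitrogen gives the strongest growth inhibitor of the four compounds, with a 5.8-fold lower number from compound 3 to compound 4 (0.76 log units; beyond the scatter) and a 5.8-fold lower number from compound 2 to compound 4 (0.77 log units; beyond the scatter) and also a 2.4-fold lower number from compound 1 to compound 4 (0.38 log units; beyond the scatter) as its steps. This position can therefore go beyond compound 1, the strongest of the earlier three. Nothing measured here explains this gain. Still open, from the compounds shown here alone, is whether the methyl or the chloro of this group matters more, and what a methoxy group or an amine in place of the methyl would give.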